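The source may report more compounds than this note shows. Statements on the series, on what has been measured and on what is new or still open speak of the compounds shown alone.

Measured in a functional assay on MDA-MB-231 cells (Homo sapiens) for antiproliferative activity, read by MTT assay, with a stated time of 48 h; on this read-out higher numbers stand for weaker inhibition and lower numbers for stronger inhibition:
compound 1 `C=CS(=O)(=O)N1CCN(c2ncnc3sc(-c4ccccc4)cc23)CC1`: 54200 nM
compound 2 `C=CS(=O)(=O)N1CCN(c2ncnc3sc(-c4ccc(OC)cc4)cc23)CC1`: 29900 nM
compound 3 `C=CS(=O)(=O)N1CCN(c2ncnc3sc(-c4cccc5ccccc45)cc23)CC1`: 23700 nM

Compound 3 has one measured neighbour within the scatter (a 1.3-fold lower number from compound 2 to compound 3 (0.10 log units; within the scatter)) and one beyond it, though only modestly (a 2.3-fold lower number from compound 1 to compound 3 (0.36 log units; beyond the scatter)). The remaining step is also within the scatter (a 1.8-fold lower number from compound 1 to compound 2 (0.26 log units; within the scatter)).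

Compound 4 `C=CS(=O)(=O)N1CCN(c2ncnc3sc(-c4ccc(OC)nc4)cc23)CC1` takes 6-methoxypyridin-3-yl in place of the naphthalen-1-yl of compound 3, on the aromatic carbon next to the ring sulfur (6-methoxypyridin-3-yl in place of naphthalen-1-yl on an aromatic carbon). Compound 2 (29900 nM) is the closest measured comparison, since it also carries a methoxy on one six-membered aromatic ring. For the measured compounds named here, no measured step shows the effect of a ring nitrogen, so this part of the change remains untested.

The steps measured so far are small, so no step beyond the scatter is expected in this assay (a 1.4-fold higher number from compound 3 to compound 4 (0.13 log units; within the scatter)). The estimated value for compound 4 is 32000 nM with an expected range from 15000 nM to 65000 nM in this series.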

Compound 4, half-maximal inhibitory concentration: 9270 nM
The estimate for compound 4 lay 3.5-fold (0.54 log units) above the measured number; measured number outside the range, below it.
By their numbers in this assay, from the lowest: compound 4; then compounds 3, 2 and 1 (each within the scatter of the next, the first and the last beyond it).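

In this assay, for the compounds shown here, 6-methoxypyridin-3-yl on the aromatic carbon next to the ring sulfur stands apart from the other three groups, with the largest gap being a 5.8-fold lower number from compound 1 to compound 4 (0.77 log units; beyond the scatter) against phenyl, so this position can move the read-out further than the earlier steps showed. Keeping the methoxy and changing the ring gives a 3.2-fold lower number from compound 2 to compound 4 (0.51 log units; beyond the scatter), the comparison closest to the effect of a ring nitrogen alone. A second aromatic ring is not needed for the lowest number here, as the swap from naphthalen-1-yl shows a 2.6-fold lower number from compound 3 to compound 4 (0.41 log units; beyond the scatter) with one six-membered aromatic ring in place of two. No measurement shown here accounts for these steps.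

Still open, from the compounds shown here alone, is whether the ring nitrogen alone carries the step, which an unsubstituted pyridin-3-yl group would test. Also open, going by these compounds, is whether the methoxy can give way to an amine or a carboxylic acid on that ring.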